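The source may report more compounds than this note shows. Statements on the series, on what has been measured and on what is new or still open speak of the compounds shown alone.

Three compounds were tested in an ADME assay on HeLa Rh cells (Homo sapiens) for cytotoxicity, read by microscopy (a lower number here means that less compound is tolerated, a higher number that more compound is tolerated), all sharing one core and differing only in the substituent on the outer aromatic ring. Compound 1 `COc1cc(CC(O)c2ccc(-c3ccc(C#N)cc3)cc2)c([N+](=O)[O-])cc1OC` carries a cyano group there, and in this assay compound 1 gives 4700 nM. Compound 2 `COc1cc(CC(O)c2ccc(-c3ccc(C)cc3)cc2)c([N+](=O)[O-])cc1OC` carries a methyl group instead, and compound 2 gives 4700 nM. Compound 3 `COc1cc(CC(O)c2ccc(-c3ccc(F)cc3)cc2)c([N+](=O)[O-])cc1OC` carries a fluoro group, and compound 3 gives 4500 nM. The swaps between these groups left the read-out essentially untouched: no change at the digits printed from compound 1 to compound 2 (within the scatter), a 1.0-fold lower number from compound 1 to compound 3 (0.02 log units; within the scatter) and a 1.0-fold lower number from compound 2 to compound 3 (0.02 log units; within the scatter). Compound 3 thus stands level with the other two, separated from compound 1 by a 1.0-fold lower number from compound 1 to compound 3 (0.02 log units; within the scatter) and from compound 2 by a 1.0-fold lower number from compound 2 to compound 3 (0.02 log units; within the scatter).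

Compound 4 `COc1cc(CC(O)c2ccc(-c3cccc(C#N)c3)cc2)c([N+](=O)[O-])cc1OC` takes the next step: 3-cyanophenyl in place of 4-fluorophenyl on an aromatic carbon. The cyano group has already been seen on this ring in compound 1, and exchanging it for fluoro gave a 1.0-fold lower number from compound 1 to compound 3 (0.02 log units; within the scatter), so the group itself did not move the number. Within the data shown here, what is new is its position on the ring, for which no measured step exists. Given that every change on this ring so far stayed within the scatter, the expected step is a 1.0-fold higher number from compound 3 to compound 4 (0.01 log units; within the scatter), none beyond the scatter. Compound 4 is therefore estimated to give 4600 nM, within a range from 2300 nM to 9200 nM.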

Compound 4, half-maximal cytotoxic concentration: 5200 nM
Compound 4: the middle estimate sits 1.1-fold (0.05 log units) below what was measured; the measured number falls inside the stated range.
By their numbers in this assay, from the lowest: compounds 3, 1, 2 and 4 (each within the scatter of the next).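

Going from 4-cyanophenyl to 3-cyanophenyl is the first step here that changes where a group sits on the outer ring rather than which group sits there, and in this assay this shift of the nitrile gives a step that stays within the scatter (a 1.1-fold higher number from compound 1 to compound 4 (0.04 log units; within the scatter)). The two other comparisons change the group and its place at once, and they also stay within the scatter (a 1.2-fold higher number from compound 3 to compound 4 (0.06 log units; within the scatter) and a 1.1-fold higher number from compound 2 to compound 4 (0.04 log units; within the scatter)), so across these four compounds neither the three groups nor the two ring positions tried separate the numbers. Why the read-out stays so flat cannot be said, as no measurement shown speaks to the cause.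

Going by these compounds, the groups on this ring so far are only a nitrile, a methyl and a fluoro, so it remains open whether an amine, a carboxylic acid or a longer chain such as butyl in the same place would shift the number beyond the scatter. All four compounds also share one core, which leaves open how much a change elsewhere in that core would matter in this assay.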